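A few compounds are considered here, and "the series" means these few. Any claim that something is new, unique, unknown or untested is made for them only; others in the source may bear on it.

Compound 1 `C=CC(=O)Nc1cccc(-c2nc3ccccc3s2)c1` and compound 2 `CN(C)CCC(=O)Nc1cccc(-c2nc3ccccc3s2)c1` share the same core and differ only in the group attached to the carbonyl carbon of the amide. In an ADME assay on Raji cells (Homo sapiens) for inhibition, with a stated time of 72 h (a lower number here means that less compound is needed, a higher number that more compound is needed for the effect), compound 1 gives > 25000 nM, which is a limit of the assay rather than a number. In this assay compound 2 gives > 25000 nM, again a limit. The change from vinyl to 2-(dimethylamino)ethyl, a step that the two limits leave unreadable from compound 1 to compound 2, therefore has no readable size. Among the compounds with values here, compound 2 thus stands on a limit, and the one further value shown is also a limit, as summarised by the limit of > 25000 nM in this assay, at which 2 of the 2 values shown sit. Compound 3 `CC(Cl)C(=O)Nc1cccc(-c2nc3ccccc3s2)c1` is the next member, carrying the change (1-chloroethyl in place of 2-(dimethylamino)ethyl on a carbonyl carbon). Within the data shown here, the only measured step, a step that the two limits leave unreadable from compound 1 to compound 2, bears on this change but offers no size and no direction, so nothing in this assay points to a move beyond the scatter, and the expectation is that compound 3 again sits at the limit. The estimate for compound 3 is 40000 nM, with an expected range from 10000 nM to 150000 nM, which as a step is expected to read a step that the limit leaves unreadable from compound 2 to compound 3.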

Compound 3, half-maximal effective concentration: > 25000 nM
Compound 3 gave a limit, no number; the forecaster's own chance of this, stated with the estimate: 85%; the middle value does not contradict the limit.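

In this assay compound 3 gives > 25000 nM as a limit of the assay and not a number, so neither step to it, from compound 1 or from compound 2, can be read. The compounds shown leave open how much of each is needed for the effect, and whether changing the group on the carbonyl carbon matters at all: the limit of > 25000 nM in this assay, at which 3 of the 3 values shown sit.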